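This account rests on a few compounds, and the source may have more. Where it says the series, first, only, none or still open, it means among the compounds named here.

Working notes on the series. In a functional assay on B16-F10 cells (Mus musculus) for antiproliferative activity, read by ELISA and MTT assay, with a stated time of 48 h (on this read-out lower numbers stand for stronger inhibition and higher numbers for weaker inhibition), compound 1 `O=C(/C=C/c1ccc(Br)cc1)NS(=O)(=O)c1ccc(Br)cc1` gives 5.1 ug/mL, and compound 2 `Cc1ccc(S(=O)(=O)NC(=O)/C=C/c2ccc(N(C)C)cc2)cc1` gives 4.3 ug/mL. Compound 2 has the smaller of these two numbers, yet the gap to compound 1 is within the usual scatter, so the two compounds cannot be told apart on the evidence in hand.

Compound 3 `CN(C)c1ccc(/C=C/C(=O)NS(=O)(=O)c2ccc(Br)cc2)cc1` is not yet measured. Relative to compound 2 the change is bromo in place of methyl on an aromatic carbon. Among the compounds with values here, no measured pair differs by only this change, so there is no measured step to lean on. Compound 1 already carries the bromo form of this ring together with a different group at the other end, and its number in this assay sits with that of compound 2. On that basis the step from compound 2 to compound 3 is expected to be none beyond the scatter, a 1.0-fold higher number from compound 2 to compound 3 (0.02 log units; within the scatter). For compound 3 the expected value is 4.5 ug/mL, with a range from 2.2 ug/mL to 9 ug/mL.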

Compound 3, half-maximal inhibitory concentration: 4.2 ug/mL
The estimate for compound 3 lay 1.1-fold (0.03 log units) above the measured number, and the stated range covers the measured number.
By their numbers in this assay, from the lowest: compounds 3, 2 and 1 (each within the scatter of the next).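

Compound 3 gives the series its first steps that differ in one place. In this assay, bromo in place of methyl on an aromatic carbon, para to a large group, gives a step within the usual scatter (a 1.0-fold lower number from compound 2 to compound 3 (0.01 log units; within the scatter)), and dimethylamino in place of bromo on the other aromatic ring also stays within it (a 1.2-fold lower number from compound 1 to compound 3 (0.08 log units; within the scatter)), so neither pair can be told apart at either end of the shared core. No measurement at hand accounts for these results.

As far as these compounds go, whether this holds for other kinds of group at the methyl and bromo position stays open, for instance a carboxylic acid, a primary amine or a longer alkyl chain. The same question stands for the dimethylamino position, where a hydrogen or a methoxy group could be compared.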